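Ring Expansion of the Lactam on a Trypsin Inhibitor

The compounds below may be only part of what the source reports. "The series", "measured", "known", "first", "only" and "open" are said of these compounds alone.

Compound 1 `Cc1nn(-c2cccc(CN)c2)c2c(F)c(-c3ccc(N4CCCC4=O)cc3)ccc12` carries a 2-oxopyrrolidin-1-yl group and a fluoro on its core. Among the compounds with values here, in an assay on isolated protein for inhibition of Trypsin (Homo sapiens) (on this read-out higher numbers stand for weaker inhibition and lower numbers for stronger inhibition), compound 1 gives 702 nM, the only plain number among the values shown. Compound 2 `Cc1nn(-c2cccc(CN)c2)c2cc(-c3ccc(N4CCCC4=O)cc3)ccc12` differs from it only by hydrogen in place of fluoro on an aromatic carbon. In this assay compound 2 gives > 10000 nM, which is a limit of the assay rather than a number (the limit of > 10000 nM in this assay, at which 1 of the 2 values shown sits). That change gave an at least 14-fold higher number from compound 1 to compound 2 (1.15 log units; beyond the scatter). Compound 3 `Cc1nn(-c2cccc(CN)c2)c2c(F)c(-c3ccc(N4CCCCC4=O)cc3)ccc12` is not yet measured; it differs from compound 1 by 2-oxopiperidin-1-yl in place of 2-oxopyrrolidin-1-yl on an aromatic carbon. Within the data shown here, the one measured step alters the fluoro, not the lactam, and offers no guide here; no step beyond the scatter is expected. The estimate for compound 3 in this assay is 700 nM, with a range from 250 nM to 2500 nM, meaning an expected step of a 1.0-fold lower number from compound 1 to compound 3 (0.00 log units; within the scatter).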

Compound 3, inhibition constant: 1900 nM
For compound 3 the middle estimate is 2.7-fold (0.43 log units) below the measured one; the range from low to high includes it.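

The lactam position responds to ring size: in this assay, the 2-oxopiperidin-1-yl group in place of 2-oxopyrrolidin-1-yl gives a 2.7-fold higher number from compound 1 to compound 3 (0.43 log units; beyond the scatter). Within the data shown here, the earlier pair changed only the fluoro, so this is the first sign that the lactam ring itself matters on this read-out. The change is modest, and compound 3 still gives a plain number, so the larger ring weakens inhibition without taking it to the assay's limit, though nothing measured here gives a cause for this step.

From the compounds shown here alone, without the fluoro, compound 2 gives > 10000 nM, which is a limit of the assay and not a number, and how the six-membered lactam behaves on a core without the fluoro stays open. Also open, going by these compounds, is whether a seven-membered lactam or an open-chain acetamide at this place would give a higher or lower number than compound 1.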